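Series notes: hydrogen in place of dimethylamino

The source may report more compounds than this note shows. Statements on the series, on what has been measured and on what is new or still open speak of the compounds shown alone.

Compound 1 `CC(C)(C)c1ccc(C(=O)/C=C/c2ccncc2)cc1` — in a functional assay with Rattus norvegicus as the target (on this read-out lower numbers stand for stronger inhibition and higher numbers for weaker inhibition), compound 1 gives 47000 nM.
Compound 2 `O=C(/C=C/c1ccncc1)c1ccc(C(F)(F)F)cc1` — in this assay compound 2 gives 204000 nM.
Compound 3 `CN(C)c1cccc(C(=O)/C=C/c2ccncc2)c1` — in this assay compound 3 gives 19000 nM.

Compound 3 gives the lowest number of the three; its gaps to compound 1 and to compound 2 both lie beyond the scatter, so it is the most potent compound measured. Compound 4 `O=C(/C=C/c1ccncc1)c1ccccc1` differs from compound 3 by hydrogen in place of dimethylamino on an aromatic carbon. Within the data shown here, the only measured step, a 4.3-fold higher number from compound 1 to compound 2 (0.64 log units; beyond the scatter), concerns a different exchange of groups on an aromatic carbon and bears only loosely on this change; no measured pair shows a substituent removed outright. Losing the dimethylamino group is therefore expected to raise the number modestly, a step of about a 2.1-fold higher number from compound 3 to compound 4 (0.32 log units; beyond the scatter) in this assay, with wide uncertainty. Compound 4 is estimated at 40000 nM, range 15000 nM to 110000 nM.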

Compound 4, half-maximal inhibitory concentration: 49000 nM
Compound 4: the middle estimate sits 1.2-fold (0.09 log units) below what was measured; the measured number falls inside the stated range.
By their numbers in this assay, from the lowest: compound 3; then compounds 1 and 4 (each within the scatter of the next); then compound 2.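

With hydrogen as the reference, dimethylamino is the only substituent shown to lower the number in this assay (a 2.6-fold higher number from compound 3 to compound 4 (0.41 log units; beyond the scatter)). Trifluoromethyl is now seen to be the group that raises it, as hydrogen in its place lowers the number (a 4.2-fold lower number from compound 2 to compound 4 (0.62 log units; beyond the scatter)), while tert-butyl cannot be told apart from hydrogen (a 1.0-fold higher number from compound 1 to compound 4 (0.02 log units; within the scatter)). No measurement bears on the cause of these steps. On these data alone, whether a primary amine or a methoxy group on the same aromatic carbon matches dimethylamino stays open. So does whether the tert-butyl and trifluoromethyl results hold at that carbon.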